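The compounds below may be only part of what the source reports. "The series", "measured", "known", "first", "only" and "open" are said of these compounds alone.

Measured compounds:
compound 1, `CC(Nc1ccccc1Oc1cccc(F)c1)=C1C(=O)CC(c2ccccc2)CC1=O`, gives 360 nM in a functional assay on HMEC-1 cells (Homo sapiens) for antiproliferative activity, read by cell counting, with a stated time of 4 days; on this read-out lower numbers stand for stronger inhibition and higher numbers for weaker inhibition.
compound 2, `COc1ccc(Oc2ccccc2NC(C)=C2C(=O)CC(c3ccccc3)CC2=O)cc1`, gives 83 nM in this assay.
compound 3, `CC(Nc1ccccc1Oc1ccc(C(C)O)cc1)=C1C(=O)CC(c2ccccc2)CC1=O`, gives 140 nM in this assay.

Compound 2 has the lowest number of the three in this assay; compound 3 sits closest to it, within the scatter, while compound 1 lies furthest away, beyond the scatter. Compound 4, `CC(Nc1ccccc1Oc1cccc(N)c1)=C1C(=O)CC(c2ccccc2)CC1=O`, has not yet been measured in this assay. It differs from compound 2 in one place: 3-aminophenyl in place of 4-methoxyphenyl on an oxygen on an aromatic ring.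

For the measured compounds named here, two measured steps bear on this change, both starting from compound 1 and replacing a 3-fluorophenyl on the same oxygen: a 4.3-fold lower number from compound 1 to compound 2 (0.64 log units; beyond the scatter) and a 2.6-fold lower number from compound 1 to compound 3 (0.41 log units; beyond the scatter). Between the two 4-substituted rings, a 1.7-fold higher number from compound 2 to compound 3 (0.23 log units; within the scatter). Going by the values given here, none of the measured steps carries a 3-aminophenyl, so the direction of the step from compound 2 is not fixed by the numbers; what is known is that compound 1, the only other 3-substituted ring, gave the highest number of the three. The change to compound 4 is therefore expected to give a modestly higher number, a 2.4-fold higher number from compound 2 to compound 4 (0.38 log units; beyond the scatter), with a wide range either way. Compound 4 is estimated at 200 nM in this assay, between 80 nM and 500 nM.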

Compound 4, half-maximal inhibitory concentration: 41 nM
Compound 4: the middle estimate sits 4.9-fold (0.69 log units) above what was measured; the whole stated range lies above it.
By their numbers in this assay, from the lowest: compound 4; then compounds 2 and 3 (each within the scatter of the next); then compound 1.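

In this assay, a 3-substituted ring on this oxygen does not by itself bring a higher number: the 3-aminophenyl ring gives a 2.0-fold lower number from compound 2 to compound 4 (0.31 log units; beyond the scatter) and a 3.4-fold lower number from compound 3 to compound 4 (0.53 log units; beyond the scatter), so neither 4-substituted ring shown is needed for the lowest number in the series. The largest step comes with the ring name otherwise unchanged, as amino in place of fluoro on an aromatic carbon gives an 8.8-fold lower number from compound 1 to compound 4 (0.94 log units; beyond the scatter), which shows that in this pair the substituent, and not the 3-substituted pattern alone, separates the two numbers. No measurement in hand accounts for these steps.

Open, as far as these compounds go, is whether amino keeps this standing as 4-aminophenyl on the same oxygen, and whether a 3-hydroxyphenyl or 3-(dimethylamino)phenyl ring would fall nearer to the 3-aminophenyl or the 3-fluorophenyl ring. The rest of the molecule is the same in all four compounds, so whether the amino step holds on any other version of the shared core also stays unanswered.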